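The source may hold more compounds than are shown below. What is called first, only, known or untested is meant among the compounds shown, and "the series" means these compounds.

Compound 1, with the structure `C=CCn1c(=O)/c(=C\c2ccccc2OC)[nH]c(=O)/c1=C\c1ccccc1OC`, carries a methoxy group on each of its two aryl rings, and in a functional assay on MOLT-4 cells (Homo sapiens) for cytotoxicity, read by CCK-8 assay, with a stated time of 72 h (on this read-out lower numbers stand for stronger inhibition and higher numbers for weaker inhibition), compound 1 gives 13100 nM. Compound 2, with the structure `C=CCn1c(=O)/c(=C\c2ccc(C)cc2)[nH]c(=O)/c1=C\c1ccccc1OC`, keeps one of those rings but bears a 4-methylphenyl on the other side; in this assay compound 2 is reported as "not active" (no number reported), so no single number marks where it stands, and it can only be said that it did not reach a measurable inhibition where compound 1 did. Compound 3, with the structure `C=CCn1c(=O)/c(=C\c2ccccc2C(F)(F)F)[nH]c(=O)/c1=C\c1ccccc1OC`, is the next member: the change is 2-(trifluoromethyl)phenyl in place of 4-methylphenyl on a double-bonded chain carbon bound to an aromatic carbon. Among the compounds with values here, no measured step connects these two compounds, so the size of the move from compound 2 to compound 3 in this assay is an open question; with compound 1 as the only compound that gave a number, a return toward a weak but measurable inhibition is expected rather than none, yet a result that again yields no number remains quite possible. For compound 3 in this assay the estimated value is 25000 nM, within a range from 8000 nM to 80000 nM.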

Compound 3, half-maximal inhibitory concentration: 4400 nM
For compound 3 the middle estimate is 5.7-fold (0.75 log units) above the measured one; the whole stated range lies above it.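

In this assay, within the data shown here, the one step that can be read is a 3.0-fold lower number from compound 1 to compound 3 (0.47 log units; beyond the scatter) with trifluoromethyl in place of methoxy on an aromatic carbon, so this substituent can be exchanged with a modest gain that lies beyond the scatter. Compound 3 also gives a number with a 2-(trifluoromethyl)phenyl on the double-bonded chain carbon where compound 2 with its 4-methylphenyl gave none, but that move cannot be read as a step of any size, since one end of it has no number. Nothing at hand accounts for either difference.

The compounds shown leave open whether a nitrile, an amine or a carboxylic acid in place of the trifluoromethyl on that aromatic carbon would carry the number further in the same direction or lose it, as happened with compound 2. They also leave open whether the methoxy-bearing ring kept on the other side in all three compounds, or the chain on the ring nitrogen, could be exchanged for another group, such as a longer chain, without losing the inhibition seen with compound 3.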